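The compounds below may be only part of what the source reports. "The series", "measured", "known", "first", "only" and "open" are said of these compounds alone.

In an ADME assay on the whole organism (Rattus norvegicus, strain Wister-Han) for pharmacokinetics, read by LC-MS, at a dose of 1 mg/kg by the intravenous route (on this read-out lower numbers stand for slow clearance and higher numbers for fast clearance), compound 2 (`CC1(C)c2cc(Cl)ccc2C(=O)N1c1cncc(OC2CN(C(=O)c3ncccc3Cl)C2)c1`) stands lowest of the three measured compounds, at 3.1 mL/min/kg. Against it, compound 1 (`Cc1ccncc1C(=O)N1CC(Oc2cncc(N3C(=O)c4ccc(Cl)cc4C3(C)C)c2)C1`) reads 15.8 mL/min/kg and compound 3 (`CC1(C)c2cc(Cl)ccc2C(=O)N1c1cncc(N2CCN(S(C)(=O)=O)CC2)c1`) reads 16.6 mL/min/kg. The next change leads to compound 4 (`CCS(=O)(=O)N1CC(Oc2cncc(N3C(=O)c4ccc(Cl)cc4C3(C)C)c2)C1`): ethylsulfonyl in place of (3-chloropyridin-2-yl)carbonyl on an amine nitrogen in a ring. This puts ethylsulfonyl in place of (3-chloropyridin-2-yl)carbonyl on an amine nitrogen in a ring.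

Among the measured compounds shown here, the one measured step touching the leaving group is a 5.1-fold lower number from compound 1 to compound 2 (0.71 log units; beyond the scatter), modest and beyond the scatter, with 3-chloropyridin-2-yl in place of 4-methylpyridin-3-yl on a carbonyl carbon. For the measured compounds named here, no measured step replaces the carbonyl with a sulfonyl group, so the evidence is indirect. Compound 3 also carries a sulfonyl group but differs from compound 4 in more than one place, and compound 3 at 16.6 mL/min/kg is only a rough guide. A rise in this assay is expected, with an estimated 3.5-fold higher number from compound 2 to compound 4 (0.55 log units; beyond the scatter). For compound 4 the estimate is 11 mL/min/kg, with an expected range of 5 mL/min/kg to 24 mL/min/kg.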

Compound 4, clearance: 3.8 mL/min/kg
Compound 4: the middle estimate sits 2.9-fold (0.46 log units) above what was measured; measured number below the stated range.
By their numbers in this assay, from the lowest: compounds 2 and 4 (each within the scatter of the next); then compounds 1 and 3 (each within the scatter of the next).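

In this assay, the swap on an amine nitrogen in a ring gives a 1.2-fold higher number from compound 2 to compound 4 (0.09 log units; within the scatter), so at this position the read-out does not depend on keeping the (3-chloropyridin-2-yl)carbonyl group, and an ethylsulfonyl group with no ring serves equally well. The same position also gives a 4.2-fold lower number from compound 1 to compound 4 (0.62 log units; beyond the scatter), so the (4-methylpyridin-3-yl)carbonyl group of compound 1 stands apart from the other two groups, and a carbonyl alone does not set the read-out here. Nothing available explains these numbers.

Open, from the compounds shown here alone, is whether a longer chain on the sulfonyl, such as propyl, or a cyclopropyl group in place of ethyl would keep the number where it stands. Also open, going by these compounds, is how a carbonyl bearing a saturated amine such as morpholine would read at this position.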